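Methoxy to ethoxy: what one added methyl may do

This account rests on a few compounds, and the source may have more. Where it says the series, first, only, none or still open, it means among the compounds named here.

compound 1 `COc1cc(C(=O)c2sc3ccccc3c2-c2ccccc2)cc(OC)c1OC`: 1500 nM
compound 2 `COc1cc(C(=O)c2sc3ccccc3c2Nc2ccc(Cl)cc2)cc(OC)c1OC`: 1900 nM
compound 3 `COc1ccc(Nc2c(C(=O)c3cc(OC)c(OC)c(OC)c3)sc3ccccc23)cc1`: 3500 nM

In a functional assay on Jurkat cells (Homo sapiens) for antiproliferative activity, read by MTT assay, with a stated time of 72 h (a lower number here means a stronger inhibitor, a higher number a weaker inhibitor), compound 3 sits within the scatter of compound 2 but beyond it from compound 1 (a 2.3-fold higher number from compound 1 to compound 3 (0.37 log units; beyond the scatter)). Compound 4 (`CCOc1ccc(Nc2c(C(=O)c3cc(OC)c(OC)c(OC)c3)sc3ccccc23)cc1`) differs from compound 3 in one place (methyl in place of hydrogen on a saturated chain carbon bound to an oxygen on an aromatic ring), which turns methoxy into ethoxy. Among the compounds with values here, no measured step lengthens such a chain. The closest measured change, methoxy in place of chloro, gave a step within the scatter (a 1.8-fold higher number from compound 2 to compound 3 (0.27 log units; within the scatter)), so only a small shift without a firm direction is expected. The expected step (a 1.2-fold lower number from compound 3 to compound 4 (0.07 log units; within the scatter)) therefore goes no further than the scatter. The estimate for compound 4 is 3000 nM with an expected range from 1200 nM to 7500 nM in this estimate.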

Compound 4, half-maximal inhibitory concentration: 300 nM
For compound 4 the middle estimate is 10-fold (1.00 log units) above the measured one; measured number outside the range, below it.
By their numbers in this assay, from the lowest: compound 4; then compounds 1, 2 and 3 (each within the scatter of the next, the first and the last beyond it).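

Adding one methyl, turning methoxy into ethoxy, gives a 12-fold lower number from compound 3 to compound 4 (1.07 log units; beyond the scatter) in this assay and is the largest step so far, so a very small change at this chain carbon can matter far more than the earlier swaps suggested. Compound 4 also moves clear of the other two compounds, with a 6.3-fold lower number from compound 2 to compound 4 (0.80 log units; beyond the scatter) and a 5.0-fold lower number from compound 1 to compound 4 (0.70 log units; beyond the scatter) on record for this series. Nothing available here explains the size of this jump.

On these data alone, whether a longer chain such as propoxy or butoxy would continue the gain remains open. So does the effect of a branched isopropoxy group or an amine at this place.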